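A few compounds are considered here, and "the series" means these few. Any claim that something is new, unique, unknown or untested is made for them only; others in the source may bear on it.

Going by the values given here, compound 2 `Cc1nc2c(OCc3ccccc3)cccn2c1Br` is the stronger of the two compounds measured so far. Among the compounds with values here, in a functional assay on the whole organism (stomach) for inhibition, with Canis familiaris (Canis lupus familiaris) as the target, at a dose of 5 mg/kg by the intravenous route (a lower number here means a weaker effect, a higher number a stronger effect of the compound at the dose given), compound 2 gives 63%, the highest of the two numbers known; its only neighbour is compound 1 `CSCc1c(C)nc2c(OCc3ccccc3)cccn12`, which in this assay gives 8%. Within the data shown here, the single measured step is a number 55 percentage points higher from compound 1 to compound 2 (beyond the scatter).

Compound 3 `Cc1nc2c(OCc3ccccc3)cccn2c1CC(=O)O` has not yet been tested. It differs from compound 2 in one place: carboxymethyl in place of bromo on an aromatic carbon. Among the measured compounds shown here, no measured step exchanges bromo for carboxymethyl, so the one known step cannot say where carboxymethyl will land; it shows only that this position is sensitive, since the move from compound 1 to compound 2 was large. For the measured compounds named here, with bromo removed from the compound that gave the highest reading, and no measured pair to show that carboxymethyl holds that level, a downward move is expected. The expected step from compound 2 to compound 3 is a number 33 percentage points lower from compound 2 to compound 3 (beyond the scatter). Compound 3 is therefore estimated to give 30%, within a range from 5% to 65%.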

Compound 3, a percentage reported as inhibition, in the whole organism at one dose (the size of the read-out at that dose, not a potency): 24%
Compound 3: the middle estimate sits 6 percentage points above what was measured; the range from low to high includes it.
By their numbers in this assay, from the lowest: compound 1; then compound 3; then compound 2.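

In this assay, the aromatic carbon that carried bromo now has a second exchange to compare: a number 39 percentage points lower from compound 2 to compound 3 (beyond the scatter), a large step, so carboxymethyl does not match bromo at the dose given. Compound 1 and compound 3 add something the earlier pair could not show, since both keep a saturated chain carbon on that aromatic carbon and differ only in what the chain carbon carries: a number 16 percentage points higher from compound 1 to compound 3 (beyond the scatter), a modest step, so the end of the chain also changes the reading, not only the atom attached to the ring. Among these three compounds, bromo, the group without a chain, gives the highest reading, although three compounds show no general rule.

No measurement here explains why either step takes the size it does. The compounds shown leave open whether chloro or an amine at this place would reach the level of bromo, and whether a longer chain ending in the carboxy group, or its methyl ester, would move the reading further from that of compound 3.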